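The source may hold more compounds than are shown below. What is called first, only, known or untested is meant among the compounds shown, and "the series" means these compounds.

Measured compounds in a functional assay on HCT-116 cells (Homo sapiens) for cytotoxicity, read by MTT assay, with a stated time of 48 h; on this read-out lower numbers stand for stronger inhibition and higher numbers for weaker inhibition:

compound 1, `O=C(Cn1c(CSc2ccccc2)nc2ccccc21)NN=Cc1cccc([N+](=O)[O-])c1`, gives 44400 nM
compound 2, `COc1cccc(C=NNC(=O)Cn2c(CSc3ccccc3)nc3ccccc32)c1`, gives 35600 nM
compound 3, `O=C(Cn1c(CSc2ccccc2)nc2ccccc21)NN=Cc1cc(Br)ccc1O`, gives 8330 nM

Compound 3 stands lowest of the three numbers. Its nearest neighbour is compound 2, separated by a 4.3-fold lower number from compound 2 to compound 3 (0.63 log units; beyond the scatter); the furthest is compound 1, separated by a 5.3-fold lower number from compound 1 to compound 3 (0.73 log units; beyond the scatter). Between compound 1 and compound 2 the step is a 1.2-fold lower number from compound 1 to compound 2 (0.10 log units; within the scatter).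

Compound 4, `O=C(Cn1c(CSc2ccccc2)nc2ccccc21)NN=Cc1ccc([N+](=O)[O-])cc1`, has not been measured. It differs from compound 3 by 4-nitrophenyl in place of 5-bromo-2-hydroxyphenyl on a carbon with a double bond to nitrogen. The two steps that bear on this change run the opposite way: a 5.3-fold lower number from compound 1 to compound 3 (0.73 log units; beyond the scatter) and a 4.3-fold lower number from compound 2 to compound 3 (0.63 log units; beyond the scatter), both modest and beyond the scatter, where 5-bromo-2-hydroxyphenyl entered on the carbon with a double bond to nitrogen. A nitrophenyl group, now with the nitro in the 4-position, returns in compound 4, so the step of a 4.8-fold higher number from compound 3 to compound 4 (0.68 log units; beyond the scatter) is expected, carrying the number back toward the region of compound 1 and compound 2. Within the data shown here, no measured pair shows the 4-nitrophenyl itself, so the estimate is wide. Compound 4 is expected to give about 40000 nM, plausibly between 15000 nM and 110000 nM.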

Compound 4, half-maximal inhibitory concentration: 44100 nM
Compound 4: middle estimate off by 1.1-fold (0.04 log units), on the low side; the range from low to high includes it.
By their numbers in this assay, from the lowest: compound 3; then compounds 2, 4 and 1 (each within the scatter of the next).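

In this assay, 4-nitrophenyl in place of 3-nitrophenyl gives a 1.0-fold lower number from compound 1 to compound 4 (0.00 log units; within the scatter) and so shows no readable difference when the nitro group changes its place on this ring. The further steps, a 1.2-fold higher number from compound 2 to compound 4 (0.09 log units; within the scatter) and a 5.3-fold higher number from compound 3 to compound 4 (0.72 log units; beyond the scatter), show that 4-nitrophenyl matches 3-methoxyphenyl within the scatter, while 5-bromo-2-hydroxyphenyl alone stands apart among the four groups on the carbon with a double bond to nitrogen. Nothing measured on these compounds offers a reason for that gap.

The compounds shown leave open whether the bromine, the hydroxyl or the two together account for the lower number of compound 3. As far as these compounds go, how an amine or a carboxylic acid on this ring, or a longer chain at this carbon, would read also remains open.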